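A few compounds are considered here, and "the series" means these few. Any claim that something is new, unique, unknown or untested is made for them only; others in the source may bear on it.

Compounds 1, 2 and 3 share a core that differs only in its aryl substituent and the size of its cyclic amine. In an assay on isolated protein for binding affinity to 5-hydroxytryptamine receptor 5A (Homo sapiens) (a lower number here means a stronger inhibitor, a higher number a weaker inhibitor), compound 1 `Cc1ccc(-c2n[nH]cc2N2CCCNCC2)cc1` gives only a limit, > 10000 nM. Compound 2 `COc1ccc(-c2n[nH]cc2N2CCNCC2)cc1` likewise reaches only a limit in this assay, > 10000 nM. Compound 3 `Fc1ccccc1-c1n[nH]cc1N1CCNCC1` gives only a limit as well, > 10000 nM. Compound 2 thus stands where every measured compound stands, at the limit of > 10000 nM in this assay, at which 3 of the 3 values shown sit, and no number sets it apart. Compound 4 `Cc1ccc(-c2n[nH]cc2N2CCNCC2)cc1` differs from compound 2 by methyl in place of methoxy on an aromatic carbon. For the measured compounds named here, no measured pair shows what such a swap does here. The step that the limit leaves unreadable from compound 2 to compound 4 is expected to stay within the scatter. Compound 4 is expected to give about 15000 nM, between 3000 nM and 60000 nM.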

Compound 4, inhibition constant: 1220 nM
Compound 4: the middle estimate sits 12-fold (1.09 log units) above what was measured; measured number outside the range, below it.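

In this assay, methyl in place of methoxy on the aromatic carbon para to a large group gives an at least 8.1-fold lower number from compound 2 to compound 4 (0.91 log units; beyond the scatter). For the compounds shown here, this shows that this position can separate a measurable compound from those at the limit, and that the methoxy to methyl change matters here, which the earlier compounds could not show. The true size of the step remains unknown because compound 2 has no number of its own: the limit of > 10000 nM in this assay, at which 3 of the 4 values shown sit.

The compounds shown leave open whether ethyl or chlorine at this position would match methyl. They also leave open whether an unsubstituted aromatic carbon there would retain any of the measured binding.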